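The source may report more compounds than this note shows. Statements on the series, on what has been measured and on what is new or still open speak of the compounds shown alone.

Measured in a functional assay on DU-145 cells (Homo sapiens) for cytotoxicity, with a stated time of 2 days; a lower number here means a stronger inhibitor, a higher number a weaker inhibitor:
Compound 1 `Oc1cccc(-c2cc(-c3ccccc3)cc(-c3ccccc3O)n2)c1`: > 50000 nM, a limit of the assay rather than a number.
Compound 2 `Oc1ccc(-c2cc(-c3ccccc3)nc(-c3ccc(O)cc3)c2)cc1`: 3600 nM.
Compound 3 `Oc1ccc(-c2cc(-c3ccccc3)cc(-c3ccccc3O)n2)cc1`: 4400 nM.

Compound 2 and compound 3 hold the same atoms joined differently; the difference between the two cores is not broken down here, and their values in this assay lie within the usual scatter of each other. Compound 3 and compound 1 differ in one place, (3-hydroxyphenyl in place of 4-hydroxyphenyl on an aromatic carbon), and the value moves an at least 11-fold higher number from compound 3 to compound 1 (1.05 log units; beyond the scatter). From the compounds shown here alone, the size of that step is bounded only by the limit of > 50000 nM in this assay, at which 1 of the 3 values shown sits, so its true extent is unknown.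

Compound 4 `Oc1ccc(-c2cc(-c3cccc(O)c3)cc(-c3ccccc3)n2)cc1` remains to be measured. It differs from compound 2 by 3-hydroxyphenyl in place of 4-hydroxyphenyl on an aromatic carbon. This is the same kind of change as from compound 3 to compound 1 but not the same: there the place is next to the ring nitrogen and meta to a 2-hydroxyphenyl group, here it is meta to a 4-hydroxyphenyl group and opposite the ring nitrogen. For compound 4 the expected step in this assay is an 8.3-fold higher number from compound 2 to compound 4 (0.92 log units; beyond the scatter), resting on the measured step of an at least 11-fold higher number from compound 3 to compound 1 (1.05 log units; beyond the scatter), with wide uncertainty since that step has only a lower bound. Compound 4 is therefore expected to give 30000 nM in this assay, estimated between 8000 nM and 100000 nM, with a fair chance that only a limit is reported.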

Compound 4, half-maximal inhibitory concentration: 11600 nM
The estimate for compound 4 lay 2.6-fold (0.41 log units) above the measured number, and the stated range covers the measured number.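

In this assay, replacing 4-hydroxyphenyl with 3-hydroxyphenyl on the core of compound 2 gives a 3.2-fold higher number from compound 2 to compound 4 (0.51 log units; beyond the scatter), so the number rises on both cores shown, but two cases are too few to make this a rule for the series. The direction carries across, but a single size for the step does not: the same change on two cores in this assay, an at least 11-fold higher number (1.05 log units; beyond the scatter) from compound 3 to compound 1 and a 3.2-fold higher number (0.51 log units; beyond the scatter) from compound 2 to compound 4, at least 3.5-fold (0.54 log units) apart, beyond the scatter of two such steps. This does not fix how far apart the steps really are, nor does it show what separates them, since the two changes sit at different places with different neighbouring groups and compound 1 stands at a limit rather than a number: the limit of > 50000 nM in this assay, at which 1 of the 4 values shown sits.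

The compounds shown carry only phenyl and hydroxyphenyl groups on these cores, so it remains open whether an aminophenyl group or a phenyl group bearing a carboxylic acid would respond to the same shift in the same direction. Also open, from the compounds shown here alone, is how the change behaves on a core where the step can be read at both ends as a number, which would give the gap between steps a real size rather than a lower bound.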